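This account rests on a few compounds, and the source may have more. Where it says the series, first, only, none or still open, it means among the compounds named here.

Measured so far:
- compound 1, `Nc1cc(N)c2nc(-c3ccccc3)c(NCc3ccc(Cl)c(Cl)c3)nc2c1`: 70800 nM
- compound 2, `COc1ccc(CNc2nc3cc(N)cc(N)c3nc2-c2ccccc2)cc1OC`: 75900 nM

In a functional assay on 786-0 cells (Homo sapiens) for inhibition, read by sulforhodamine B assay, with a stated time of 48 h (on this read-out lower numbers stand for higher toxicity in this test and higher numbers for lower toxicity in this test), compound 2 holds the highest of the two numbers; its nearest neighbour is compound 1, with a 1.1-fold higher number from compound 1 to compound 2 (0.03 log units; within the scatter) separating the two. Compound 3, `COc1cc(CNc2nc3cc(N)cc(N)c3nc2-c2ccccc2)cc(OC)c1OC`, carries methoxy in place of hydrogen on an aromatic carbon on the same ring that was exchanged in that step. For the measured compounds named here, the only step that bears on this change, the exchange of the whole ring between compound 1 and compound 2, stayed within the scatter, so no step beyond the scatter is expected in this assay for compound 3 either. Compound 3 is therefore estimated at 76000 nM, within 30000 nM to 190000 nM, which means an expected step of a 1.0-fold higher number from compound 2 to compound 3 (0.00 log units; within the scatter).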

Compound 3, concentration lethal to 50% of the cells: < 50200 nM
Compound 3: a limit, no number (the forecaster's own chance of this, stated with the estimate: 10%); middle value at least 1.5-fold (0.18 log units) away from the limit.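

In this assay compound 3 gives < 50200 nM, which is a limit of the assay and not a number. Methoxy in place of hydrogen on an aromatic carbon, ortho to a methoxy group, gives an at least 1.5-fold lower number from compound 2 to compound 3 (0.17 log units; that floor lies within the scatter), so this single position can shift the read-out downward, although the size of the shift remains unfixed. The reading therefore rests on one censored value: the limit of < 50200 nM in this assay, at which 1 of the 3 values shown sits.

On these data alone, how far compound 3 actually lies under its limit stays open. As far as these compounds go, whether a hydroxy group, an amine or a longer alkoxy chain on this aromatic carbon would read the same also stays open.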